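The source may hold more compounds than are shown below. What is called first, only, known or untested is meant among the compounds shown, and "the series" means these compounds.

Measured compounds:
- Compound 1 `CC(C)C[C@H](N)C(=O)NS(=O)(=O)OC[C@H]1O[C@@H](n2cnc3c(N)ncnc32)[C@H](O)[C@@H]1O`: in a functional assay on PBMC cells (Homo sapiens) for inhibition (on this read-out lower numbers stand for stronger inhibition and higher numbers for weaker inhibition), compound 1 gives 1100 nM
- Compound 2 `Nc1ncnc2c1ncn2[C@@H]1O[C@H](COS(=O)(=O)NC(=O)[C@@H]2CCN2)[C@@H](O)[C@H]1O`: in this assay compound 2 gives 600 nM

Within the data shown here, compound 2 holds the lower of the two numbers in this assay, but the only step that separates it from compound 1, a 1.8-fold lower number from compound 1 to compound 2 (0.26 log units; within the scatter), lies within the scatter, so the two compounds cannot be ranked against each other on these data.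

Compound 3 `CC(C)[C@H](N)C(=O)NS(=O)(=O)OC[C@H]1O[C@@H](n2cnc3c(N)ncnc32)[C@H](O)[C@@H]1O` is not yet measured. It differs from compound 2 in one place: 1-amino-2-methylpropyl in place of azetidin-2-yl on a carbonyl carbon. Among the measured compounds shown here, the sole measured step that bears on this change is the one from compound 1 to compound 2, a 1.8-fold lower number from compound 1 to compound 2 (0.26 log units; within the scatter), in which a branched amino-alkyl group gave way to the azetidin-2-yl ring with no effect beyond the scatter. Compound 3 reverses that kind of exchange, returning to a branched amino-alkyl group on the carbonyl carbon, so the step in this assay is expected to be small and, if anything, a slightly higher number, a 1.7-fold higher number from compound 2 to compound 3 (0.22 log units; within the scatter).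

Compound 3 is therefore expected to give about 1000 nM in this assay, with a range of 350 nM to 3000 nM.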

Compound 3, half-maximal inhibitory concentration: 5600 nM
Estimate against measurement, compound 3: 5.6-fold (0.75 log units) below; measured number above the stated range.
By their numbers in this assay, from the lowest: compounds 2 and 1 (each within the scatter of the next); then compound 3.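

In this assay, among these compounds, the group on the carbonyl carbon is not as interchangeable as the first pair of compounds suggested: the exchange of azetidin-2-yl for 1-amino-2-methylpropyl gives a 9.3-fold higher number from compound 2 to compound 3 (0.97 log units; beyond the scatter) and so moves the read-out well past the scatter. The open-chain groups also differ from each other, since isopropyl in place of isobutyl on the saturated chain carbon gives a 5.1-fold higher number from compound 1 to compound 3 (0.71 log units; beyond the scatter) and so a small change within the amino-alkyl group is enough to shift the result. The close values of compound 1 and compound 2 therefore hold for that pair alone and do not extend to every amino-alkyl group at this place, and no available evidence accounts for the higher number of compound 3.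

These three compounds leave open whether a pyrrolidin-2-yl ring on the carbonyl carbon would read like compound 2 or like compound 3. They also leave open how an unbranched n-butyl chain carrying the same amine would compare, or whether a hydroxyl group could take the place of that amine.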